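This account rests on a few compounds, and the source may have more. Where it says the series, first, only, none or still open, it means among the compounds named here.

Two pyrazoles built on the same three-ring arrangement were examined for their effect on liver-derived cells. Compound 1 `Fc1ccc(-c2cc(-c3ccc4cc(F)ccc4n3)n(-c3ccccc3)n2)cc1` and compound 2 `Fc1ccc(-n2nc(-c3ccccc3)cc2-c2ccc3cc(F)ccc3n2)cc1` carry the same fluoro-substituted bicyclic group and two benzene rings, arranged differently around the central five-membered ring. In an ADME assay on Huh-7 cells (Homo sapiens) for cytotoxicity, read by XTT assay, with a stated time of 3 days, tested at 20 uM (a higher number here means a weaker effect of the compound at the concentration tested, a lower number a stronger effect), compound 1 gives 88.1%, and in this assay compound 2 gives 97.8%; the two readings lie within the usual scatter of each other, so neither can be called the more or less damaging of the pair, and both leave most of the cells viable at the concentration tested.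

Compound 3 `Fc1ccc(-c2cc(-c3ccc4cc(F)ccc4n3)n(-c3ccc(F)cc3)n2)cc1` is the next member. Relative to compound 2 it differs by fluoro in place of hydrogen on an aromatic carbon. For the measured compounds named here, nothing among the measured compounds shows what such a change does here, so the expectation rests on the two readings alone, which both sit high. No step beyond the scatter is expected; the estimated change from compound 2 to compound 3 is a number 4.8 percentage points lower from compound 2 to compound 3 (within the scatter). Compound 3 is therefore expected to give about 93%, within a range from 78% to 100%.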

Compound 3, a percentage reported as activity, at one concentration (the size of the read-out at that concentration, not a potency): 95.3%
Compound 3: the middle estimate sits 2.3 percentage points below what was measured, and the stated range covers the measured number.
By their numbers in this assay, from the lowest: compounds 1, 3 and 2 (each within the scatter of the next).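

With fluoro added to the second benzene ring, the phenyl to 4-fluorophenyl change can now be read from both sides: in this assay it gives a number 2.5 percentage points lower from compound 2 to compound 3 (within the scatter) and, on the other benzene ring, a number 7.2 percentage points higher from compound 1 to compound 3 (within the scatter) as well. Together, these steps show that at this concentration fluoro para to a large group can stand on either benzene ring, or on both at once, without a step beyond the scatter, which the first two compounds, each with a single fluorinated benzene ring and differing in its arrangement, could not show. No independent measurement bears on why the readings stay so close together.

As far as these compounds go, what remains open is whether a group other than fluoro at this place, such as a methoxy group, an amine or a carboxylic acid, would leave the reading where it stands. All three compounds also keep the same fluoro-substituted bicyclic group, so the part played by that fluoro stays unresolved, and a reading at one concentration gives no potency for any of them.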